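Ring opened to chain on the acylguanidine of compound 1

The source may hold more compounds than are shown below. What is called first, only, known or untested is meant among the compounds shown, and "the series" means these compounds.

compound 1 `N/C(=N\C(=O)NC1CCCCC1)Nc1cccc(-c2csc(N)n2)c1`: 4470 nM
compound 2 `Cc1nc(N)sc1CCCN/C(N)=N/C(=O)NC1CCCCC1`: 170 nM
compound 3 `Cc1nc(N)sc1CCCN/C(N)=N/C(=O)NCC(C)CCc1ccccc1`: 63.1 nM

Of the compounds shown here, three have so far been tested in an assay on membranes from Sf9 cells for displacement of a labelled ligand from histamine H2 receptor (Homo sapiens), read by scintillation counting, with a stated time of 60 min; on this read-out higher numbers stand for weaker inhibition and lower numbers for stronger inhibition. Compound 1 gives 4470 nM, the highest of the three numbers; compound 2 sits well lower at 170 nM, and compound 3 lower still at 63.1 nM, both gaps beyond the scatter. Going by the values given here, compounds 2 and 3, however, share a core of their own that differs from compound 1 in more than one place, so no single-change step between measured compounds can be drawn, and compound 1 stands on its own at the weak end of what has been measured.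

The unmeasured compound 4 `CCCCCCNC(=O)/N=C(\N)Nc1cccc(-c2csc(N)n2)c1` keeps the core of compound 1 and alters a single group: hexyl in place of cyclohexyl on an amide-type nitrogen. Among the compounds with values here, nothing among the measured compounds shows a change of this kind, and the step of a 1.3-fold lower number from compound 1 to compound 4 (0.11 log units; within the scatter) is therefore expected to be small, in either direction or none beyond the scatter. Compound 4 is expected to give about 3500 nM, within 1200 nM to 10000 nM.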

Compound 4, inhibition constant: 692 nM
For compound 4 the middle estimate is 5.1-fold (0.70 log units) above the measured one, outside the stated range (below it).
By their numbers in this assay, from the lowest: compound 3; then compound 2; then compound 4; then compound 1.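

In this assay, going by these compounds alone, replacing cyclohexyl with hexyl on the amide-type nitrogen gives a 6.5-fold lower number from compound 1 to compound 4 (0.81 log units; beyond the scatter), the first single-change step and one beyond the scatter. Within the data shown here, the two groups have the same carbon count and neither has hydrogen-bond donors or acceptors, so the step shows that this position responds to a ring of carbon being replaced by an open chain, a sensitivity that the earlier compounds could not reveal. Nothing in the data accounts for this difference.

Going by these compounds, whether other open chains, such as butyl or octyl, or a smaller ring such as cyclopentyl, would follow compound 4 remains open. On these data alone, it is also open whether hexyl would have a similar effect on the core of compound 2.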